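Ring exchange on the alkyne arm of the shared core

A few compounds are considered here, and "the series" means these few. Any claim that something is new, unique, unknown or untested is made for them only; others in the source may bear on it.

Going by the values given here, compound 3 `C#Cc1cc(C#Cc2ccc3ncn(-c4ccnc(N)n4)c3c2)ncn1` gives 50100 nM in an assay on Sf9 cells for inhibition of mitogen-activated protein kinase kinase kinase 14 variant S549D (Homo sapiens), with a stated time of 30 min, in the presence of a further agent that is not named here (on this read-out lower numbers stand for stronger inhibition and higher numbers for weaker inhibition), and sits at the high end of the three numbers so far: compound 2 `C=Cc1nccc(C#Cc2ccc3ncn(-c4ccnc(N)n4)c3c2)n1` gives 39800 nM and compound 1 `C=Cc1cc(C#Cc2ccc3ncn(-c4ccnc(N)n4)c3c2)ccn1` gives 20000 nM, the distances being a 1.3-fold higher number from compound 2 to compound 3 (0.10 log units; within the scatter) and a 2.5-fold higher number from compound 1 to compound 3 (0.40 log units; beyond the scatter). Compound 4 `C#Cc1cncc(C#Cc2ccc3ncn(-c4ccnc(N)n4)c3c2)n1` differs from compound 3 by a group of 8 heavy atoms (6 carbon, 2 nitrogen; one six-membered aromatic ring with 2 hetero atoms) in place of a group of 8 heavy atoms (6 carbon, 2 nitrogen; one six-membered aromatic ring with 2 hetero atoms), on a triple-bonded carbon. The earlier exchanges of one ring for another on the triple-bonded carbon gave a 2.0-fold higher number from compound 1 to compound 2 (0.30 log units; within the scatter) and a 1.3-fold higher number from compound 2 to compound 3 (0.10 log units; within the scatter), both small, and a 2.5-fold higher number from compound 1 to compound 3 (0.40 log units; beyond the scatter) only slightly beyond the scatter. A small step, or none beyond the scatter, is therefore expected in this assay for compound 4. The estimated value for compound 4 is 50000 nM, with a range from 20000 nM to 125000 nM. The expected step is a 1.0-fold lower number from compound 3 to compound 4 (0.00 log units; within the scatter).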

Compound 4, half-maximal inhibitory concentration: 6310 nM
For compound 4 the middle estimate is 7.9-fold (0.90 log units) above the measured one; the whole stated range lies above it.
By their numbers in this assay, from the lowest: compound 4; then compounds 1, 2 and 3 (each within the scatter of the next, the first and the last beyond it).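

On the triple-bonded carbon, an exchange of rings with the same atoms joined differently is not neutral in this assay: the two groups have identical counts, yet the number drops (a 7.9-fold lower number from compound 3 to compound 4 (0.90 log units; beyond the scatter)). Compound 4 also stands clear of the other two (a 6.3-fold lower number from compound 2 to compound 4 (0.80 log units; beyond the scatter); a 3.2-fold lower number from compound 1 to compound 4 (0.50 log units; beyond the scatter)), making it the strongest of the four. No measurement bears on what lies behind this step.

On these data alone, whether the lower number persists with an amine or a carboxylic acid on this ring in place of the terminal alkyne remains open.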